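Replacing a methyl with a methylpyrimidine on an amide

The source may hold more compounds than are shown below. What is called first, only, known or untested is meant among the compounds shown, and "the series" means these compounds.

This series is followed in a physicochemical assay for solubility, measured as kinetic solubility, with a stated time of 1 h, at pH 7.4; a higher number here means a more soluble compound, a lower number a less soluble compound. Compound 1 `N#CCC(=O)Nc1ccn(-c2ccc(Cl)c(Cl)c2)n1` carries a nitrile-bearing side chain on an amide and gives 34000 nM in this assay. Compound 2 `CC(=O)NC1=NN(c2ccc(Cl)c(Cl)c2)CC1` keeps the same dichlorophenyl group on a shared core but carries a plain acetamide; in this assay compound 2 gives 31000 nM. Among the compounds with values here, with only two numbers recorded, compound 2 sits alongside compound 1, and the gap between them lies within the usual scatter, so neither can be called more or less soluble than the other.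

Compound 3 `Cc1ncncc1C(=O)NC1=NN(c2ccc(Cl)c(Cl)c2)CC1` has not yet been measured. It differs from compound 2 in one place: 4-methylpyrimidin-5-yl in place of methyl on a carbonyl carbon. Within the data shown here, no measured pair of compounds here shows a change of this kind, so there is no recorded step to lean on. The expectation for compound 3 is a moderate drop in this assay, a step of a 2.1-fold lower number from compound 2 to compound 3 (0.32 log units; beyond the scatter) that is somewhat larger than the scatter but not dramatic. Compound 3 is therefore estimated at 15000 nM in this assay, with a plausible range from 5000 nM to 40000 nM.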

Compound 3, solubility: 12000 nM
The estimate for compound 3 lay 1.3-fold (0.10 log units) above the measured number; measured number inside the range.
By their numbers in this assay, from the lowest: compound 3; then compounds 2 and 1 (each within the scatter of the next).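

Within the data shown here, at the carbonyl carbon of the amide, putting 4-methylpyrimidin-5-yl in place of methyl gives, in this assay, a 2.6-fold lower number from compound 2 to compound 3 (0.41 log units; beyond the scatter), the first change in one place that can be read in this set. This shows that the number does respond to what sits at this position, although the step is modest for a change that swaps 1 heavy atom for 7 heavy atoms and adds a six-membered aromatic ring with 2 hydrogen-bond acceptors. No measurement presented here accounts for the step, which therefore stands as an observation only.

Among these compounds, the single step cannot separate the pyrimidine ring from the methyl it carries, so it remains open whether a plain pyrimidin-5-yl, a phenyl or a piperidine on the same carbonyl carbon would read closer to compound 2 or to compound 3. From the compounds shown here alone, compound 1 differs from compound 2 in more than one place, so it also remains open whether the same exchange would give a step of similar size on the core of compound 1.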